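Shrinking the amide ring: compound 1 to compound 4

A few compounds are considered here, and "the series" means these few. Any claim that something is new, unique, unknown or untested is made for them only; others in the source may bear on it.

Three compounds have been measured in an assay on isolated protein for inhibition of aldehyde dehydrogenase 1A1 (Homo sapiens), read by spectrophotometry, tested at 10 uM; a lower number here means less inhibition, a higher number more inhibition at the concentration tested (going by the name of the read-out):

Compound 1 `Cc1cccc(Cn2c(CN3CCN(C(=O)C4CCCCC4)CC3)nc3ccccc32)c1`: 31.9%
Compound 2 `O=C(C1CC1)N1CCN(Cc2nc3ccccc3n2Cc2cccc(F)c2)CC1`: 27.2%
Compound 3 `O=C(C1CC1)N1CCN(Cc2nc3ccccc3n2Cc2ccc(C(F)(F)F)cc2)CC1`: 37%

Compound 1 gives a number that lies within the usual scatter of both compound 2 and compound 3, so on these readings the three cannot be told apart.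

Compound 4 `Cc1cccc(Cn2c(CN3CCN(C(=O)C4CCC4)CC3)nc3ccccc32)c1` is not yet measured. It differs from compound 1 in one place: cyclobutyl in place of cyclohexyl on a carbonyl carbon.

For the measured compounds named here, only one measured step is at hand, a number 9.8 percentage points higher from compound 2 to compound 3 (within the scatter), and it changes the group on the saturated chain carbon bound to the aromatic nitrogen, not the group on the carbonyl carbon. Compound 2 and compound 3 carry cyclopropyl on that carbonyl carbon where compound 1 carries cyclohexyl, yet they differ from compound 1 elsewhere too, and their values are within the scatter of the value of compound 1. Going by the values given here, no step therefore bears directly on the change to compound 4, and the step expected is a number 1.9 percentage points lower from compound 1 to compound 4 (within the scatter), that is, none beyond the scatter.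

For compound 4 the expected value in this assay is 30%, within a range from 15% to 45%.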

Compound 4, a percentage reported as inhibition, at one concentration (the size of the read-out at that concentration, not a potency): 69.1%
Estimate against measurement, compound 4: 39.1 percentage points below; measured number outside the range, above it.
By their numbers in this assay, from the lowest: compounds 2, 1 and 3 (each within the scatter of the next); then compound 4.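

The group on the carbonyl carbon turns out to matter in this assay: cyclobutyl in place of cyclohexyl gives a number 37.2 percentage points higher from compound 1 to compound 4 (beyond the scatter). This is the only step shown that lies beyond the usual scatter, whereas the one earlier step, a number 9.8 percentage points higher from compound 2 to compound 3 (within the scatter), changed a different part of the molecule and could not be told from noise. A change limited to this ring, from six-membered to four-membered, with the rest of the molecule the same, is therefore enough to move the reading clearly. No measurement at hand explains why.

As far as these compounds go, it remains open whether cyclopentyl or an open chain such as tert-butyl on this carbonyl carbon would read closer to compound 1 or to compound 4. From the compounds shown here alone, it is also open whether cyclobutyl would bring a similar rise alongside the 4-(trifluoromethyl)phenyl group of compound 3.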